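Removing the methyl from compound 2: an open question

A few compounds are considered here, and "the series" means these few. Any claim that something is new, unique, unknown or untested is made for them only; others in the source may bear on it.

Compound 2, `Cc1ccnc(/C(N)=N/NC(=S)N2CCSCC2)c1`: 76.8%
Compound 1, `Cc1cccc(/C(N)=N/NC(=S)N2CCSCC2)n1`: 46.8%

Of the compounds shown here, two have been measured in a functional assay on MCF7 cells (Homo sapiens) for cytotoxicity, read by MTT assay, with a stated time of 72 h, tested at 100 uM; on this read-out lower numbers stand for less inhibition of growth and higher numbers for more inhibition of growth at the one concentration tested. Compound 2 stands highest of the two numbers; its nearest neighbour, compound 1, gives 46.8%, a figure well below it and beyond the scatter. For the measured compounds named here, the two share a core and differ only in where a methyl sits on the ring, so their values show a wide spread, but no single computed step links them.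

Compound 3, `N/C(=N\NC(=S)N1CCSCC1)c1ccccn1`, is the unmeasured member. Going from compound 2 to compound 3, the change is hydrogen in place of methyl on an aromatic carbon. Going by the values given here, no measured pair shows what removing that methyl does, so the direction is open; a step of either sign, or none beyond the scatter, remains possible, and the spread between compound 1 and compound 2 argues for caution.

For compound 3 the value in this assay is estimated at 62%, between 35% and 85%, which would mean an expected step of a number 14.8 percentage points lower from compound 2 to compound 3 (beyond the scatter).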

Compound 3, percent growth inhibition at one concentration: 72.4%
For compound 3 the middle estimate is 10.4 percentage points below the measured one; measured number inside the range.
By their numbers in this assay, from the lowest: compound 1; then compounds 3 and 2 (each within the scatter of the next).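

In this assay, taking away the methyl opposite the ring nitrogen gives a number 4.4 percentage points lower from compound 2 to compound 3 (within the scatter) and so leaves the read-out unmoved at this place on the ring, within the scatter. The same exchange on compound 1 gives a number 25.6 percentage points higher from compound 1 to compound 3 (beyond the scatter) and lies beyond the scatter, so hydrogen in place of methyl does not read alike at the two places, and among these three compounds only compound 1 stands apart. Nothing available here accounts for that difference.

As far as these compounds go, whether a larger group at the place opposite the ring nitrogen, such as an amine, a carboxylic acid or a longer chain, would keep the read-out where it stands remains open. The compounds shown also leave open how they would compare at other concentrations, since each has a figure at a single concentration only.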